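A Chloro for a Methyl on the Sulfonamide Ring

The compounds below may be only part of what the source reports. "The series", "measured", "known", "first", "only" and "open" are said of these compounds alone.

Compound 2 `Cc1ccc(S(=O)(=O)NCc2cn(Cc3cc(=O)oc4cc(O)ccc34)nn2)cc1` is the only one of these compounds with a number: in a functional assay on HepG2 cells (Homo sapiens) for inhibition, read by MTT assay, with a stated time of 72 h (a lower number here means a stronger inhibitor, a higher number a weaker inhibitor), compound 2 gives 29800 nM. Within the data shown here, compound 1 `O=c1cc(Cn2cc(CCCCl)nn2)c2ccc(O)cc2o1` reaches only a limit in this assay, > 100000 nM, so compound 2 stands beside the limit of > 100000 nM in this assay, at which 1 of the 2 values shown sits, as the sole measured value. Compound 3 `O=c1cc(Cn2cc(CNS(=O)(=O)c3ccc(Cl)cc3)nn2)c2ccc(O)cc2o1` differs from compound 2 by chloro in place of methyl on an aromatic carbon. With no such step measured among these compounds, only a small change is expected, a 1.2-fold lower number from compound 2 to compound 3 (0.08 log units; within the scatter), in no clear direction beyond the usual scatter. Compound 3 is estimated at 25000 nM, within a range of 9000 nM to 70000 nM.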

Compound 3, half-maximal inhibitory concentration: 31400 nM
Beside the measured number, compound 3's estimate is 1.3-fold (0.10 log units) below it; measured number inside the range.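

The swap from 4-methylphenyl to 4-chlorophenyl gives a 1.1-fold higher number from compound 2 to compound 3 (0.02 log units; within the scatter) in this assay, the first step among these compounds that can be read. At this ring position, then, methyl and chloro cannot be told apart in this assay, and the number stays in the same range with either group. Nothing shown here bears on why the two groups read alike.

As far as these compounds go, what stays open is whether a quite different group on that ring carbon, such as an amine, a carboxylic acid or a longer chain, would move the number beyond the scatter.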